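The source may report more compounds than this note shows. Statements on the series, on what has been measured and on what is new or still open speak of the compounds shown alone.

Measured so far in an ADME assay on microsomes from liver (Homo sapiens) for metabolic stability, with a stated time of 30 min; a lower number here means that less of the compound is left, a higher number that more of the compound is left:

compound 1 `CCCCOC(=O)Cc1c(C)nc(CCCC)n(Cc2ccc(-c3ccccc3-c3noc(=O)[nH]3)cc2)c1=O` — 2.8%
compound 2 `CCCCc1nc(C)c(CC(=O)OCC(C)C)c(=O)n1Cc1ccc(-c2ccccc2-c2noc(=O)[nH]2)cc1` — 2.4%

Compound 2 gives 2.4% in this assay, and compound 1 sits within the scatter of it; the step of a number 0.4 percentage points lower from compound 1 to compound 2 (within the scatter) shows no difference beyond repeat variation between the two.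

Compound 3 `CCCCc1nc(C)c(CC(=O)OCC2CC2)c(=O)n1Cc1ccc(-c2ccccc2-c2noc(=O)[nH]2)cc1` is not yet measured. It differs from compound 2 in one place: cyclopropyl in place of isopropyl on a saturated chain carbon bound to an oxygen next to a carbonyl group.

Among the measured compounds shown here, the only measured step at the same place, a number 0.4 percentage points lower from compound 1 to compound 2 (within the scatter), was within the scatter. The change from compound 2 to compound 3 again exchanges one three-carbon group for another at that position, so nothing in the two measured compounds points to a step beyond the scatter in this assay.

Compound 3 is therefore expected near compound 2, with the estimated step of a number 0.6 percentage points higher from compound 2 to compound 3 (within the scatter). The estimate for compound 3 is 3%, with a range from 0.5% to 12%.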

Compound 3, percent of the compound remaining: 20%
Beside the measured number, compound 3's estimate is 17 percentage points below it, outside the stated range (above it).
By their numbers in this assay, from the lowest: compounds 2 and 1 (each within the scatter of the next); then compound 3.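

At this position, on a saturated chain carbon bound to an oxygen next to a carbonyl group, the group does affect the read-out in this assay: cyclopropyl in place of isopropyl gives a number 17.6 percentage points higher from compound 2 to compound 3 (beyond the scatter), and cyclopropyl in place of propyl gives a number 17.2 percentage points higher from compound 1 to compound 3 (beyond the scatter). Isopropyl and cyclopropyl both have 3 heavy atoms, so among these compounds the change that counts is one that adds a three-membered ring with no change in heavy-atom count, and compound 3 alone stands apart from the two open-chain compounds. No measured information bears on the cause of this step.

As far as these compounds go, whether the higher number extends to other rings remains open, as a cyclobutyl group at this place would test. A longer chain or a carboxylic acid there also remains unplaced relative to compound 3.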